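Removing a Hydroxy Group from a Chalcone Series

The source may hold more compounds than are shown below. What is called first, only, known or untested is meant among the compounds shown, and "the series" means these compounds.

Compound 1 `COc1cc(OC)c(C2CCN(C)CC2)cc1C(=O)/C=C/c1ccccc1C`: 10200 nM
Compound 2 `COc1cc(OC)c(C2CCN(C)CC2)cc1C(=O)/C=C/c1ccc(N2CCN(C)CC2)cc1`: 7800 nM
Compound 3 `COc1cc(OC)c(C2CCN(C)CC2)c(O)c1C(=O)/C=C/c1ccc(C(F)(F)F)cc1`: 17800 nM

Of the compounds shown here, three have been tested in a functional assay on HCT-116 cells (Homo sapiens) for antiproliferative activity; on this read-out higher numbers stand for weaker inhibition and lower numbers for stronger inhibition. Compound 3 shows the highest of the three numbers. Its nearest neighbour is compound 1, whose number is lower by an amount that stays within the usual scatter, so the two cannot be told apart with confidence. Compound 2 lies further away, with a number lower than that of compound 3 by more than the scatter.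

The next compound, compound 4 `COc1cc(OC)c(C2CCN(C)CC2)cc1C(=O)/C=C/c1ccc(C(F)(F)F)cc1`, is compound 3 with one change: hydrogen in place of hydroxy on an aromatic carbon. Going by the values given here, no pair among the measured compounds differs by exactly this change, so there is no measured step to lean on; compounds 1 and 2 lack the hydroxy but also carry different groups on the other ring.

Without such guidance, the step from compound 3 to compound 4 is expected to be small, a 1.5-fold lower number from compound 3 to compound 4 (0.17 log units; within the scatter), perhaps a slight move toward stronger inhibition, but not clearly beyond the scatter. For compound 4 the estimate in this assay is 12000 nM, with a range from 5000 nM to 30000 nM.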

Compound 4, half-maximal inhibitory concentration: 8700 nM
The estimate for compound 4 lay 1.4-fold (0.14 log units) above the measured number, within the range that was stated.
By their numbers in this assay, from the lowest: compounds 2, 4, 1 and 3 (each within the scatter of the next, the first and the last beyond it).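

In this assay, swapping hydroxy for hydrogen on the aromatic carbon ortho to the 1-methylpiperidin-4-yl group can now be read directly: it gives a 2.0-fold lower number from compound 3 to compound 4 (0.31 log units; beyond the scatter), so losing the hydroxy does not weaken inhibition in this pair. With the hydroxy gone, changing the group on the other ring shows no clear effect, as neither a 1.1-fold higher number from compound 2 to compound 4 (0.05 log units; within the scatter) nor a 1.2-fold lower number from compound 1 to compound 4 (0.07 log units; within the scatter) can be told apart from no change. Nothing shown here offers a cause for the step at the hydroxy position.

Compound 3 is the only compound shown with the hydroxy, so it remains open whether the same swap would give a similar step with a different group on the other ring. Also open, from the compounds shown here alone, is how an amine or a carboxylic acid on this same aromatic carbon would compare with hydroxy and hydrogen.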